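Swapping hydroxy for pyrrolidin-1-yl on compound 3

The source may report more compounds than this note shows. Statements on the series, on what has been measured and on what is new or still open speak of the compounds shown alone.

Three closely related compounds have been measured in an in vitro ADME assay on microsomes (Homo sapiens) for metabolic stability; a lower number here means slower removal, a higher number faster removal of the compound. Compound 1 (`CC1CN(CC(=O)Nc2ccc(-n3ccccc3=O)cc2F)CC1NC(=O)c1ccc(Cl)s1`) gives 76.3 mL.min-1.g-1. Compound 2 (`O=C(CN1CC(NC(=O)c2ccc(Cl)s2)C(C2CC2)C1)Nc1ccc(-n2ccccc2=O)cc1F`) gives 267 mL.min-1.g-1. Compound 3 (`O=C(CN1C[C@H](NC(=O)c2ccc(Cl)s2)C[C@H]1CO)Nc1ccc(-n2ccccc2=O)cc1F`) stands lowest of the three at 7 mL.min-1.g-1, and its distance to each of the other two lies beyond the scatter.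

Compound 4 (`O=C(CN1C[C@H](NC(=O)c2ccc(Cl)s2)C[C@H]1CN1CCCC1)Nc1ccc(-n2ccccc2=O)cc1F`) departs from compound 3 in one place, with pyrrolidin-1-yl in place of hydroxy on a saturated chain carbon bound to a saturated ring carbon. Going by the values given here, no measured pair shows a replacement of hydroxy, so only one step bears on this change, and only loosely. That step is a 3.5-fold higher number from compound 1 to compound 2 (0.54 log units; beyond the scatter), a modest one beyond the scatter, with cyclopropyl in place of methyl on a saturated ring carbon. In both swaps a group with a ring enters where none stood, but the places differ, so the step offers a direction more than a size. On that single precedent, a rise beyond the scatter is expected in this assay, estimated as a 5.0-fold higher number from compound 3 to compound 4 (0.70 log units; beyond the scatter). Compound 4 is expected at 35 mL.min-1.g-1, with an estimated range from 12 mL.min-1.g-1 to 120 mL.min-1.g-1.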

Compound 4, intrinsic clearance in microsomes: 61.4 mL.min-1.g-1
Compound 4: middle estimate off by 1.8-fold (0.24 log units), on the low side; low and high end bracket the measured number.
By their numbers in this assay, from the lowest: compound 3; then compounds 4 and 1 (each within the scatter of the next); then compound 2.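

Going by these compounds alone, this is the first measured change on a saturated chain carbon bound to a saturated ring carbon, and in this assay the swap of hydroxy for pyrrolidin-1-yl gives an 8.8-fold higher number from compound 3 to compound 4 (0.94 log units; beyond the scatter), so the number at this place moves with what the chain carries. Within the data shown here, the single swap changes several things at once: a hydroxy with a hydrogen-bond donor leaves, while a pyrrolidin-1-yl with a five-membered non-aromatic ring, a nitrogen and no hydrogen-bond donor enters, and the pair cannot show which of these differences accounts for the rise. Nothing measured beyond these numbers offers an explanation for the step.

The compounds shown leave open whether the hydroxy itself matters or whether the rise follows the incoming amine, which a methoxy, a dimethylamino or a morpholin-4-yl group at the same place, or a carboxylic acid there, would help to separate. They also leave open whether hydroxymethyl to (pyrrolidin-1-yl)methyl would give a step of similar size on a ring bearing other groups.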